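The source may hold more compounds than are shown below. What is called first, only, known or untested is meant among the compounds shown, and "the series" means these compounds.

Within the data shown here, in a physicochemical assay for lipophilicity, read by HPLC, measured as chromatographic lipophilicity, at pH 7.4 (on this read-out lower numbers stand for lower lipophilicity and higher numbers for higher lipophilicity), compound 3 (`O=C(C1CCC1)N1N=CCC1c1ccccc1`) gives (4.7), the second highest of the three numbers so far. Compound 1 (`CC(C)(C)C(=O)N1N=CCC1c1cc(F)cc(F)c1`) stands higher (6.3) and compound 2 (`O=C(c1cccnc1)N1N=CCC1c1ccccc1`) stands lower (2.7), both gaps beyond the scatter.

The next compound is compound 4 (`CC(C)(CN)C(=O)N1N=CCC1c1ccccc1`), with 1-(aminomethyl)-1-methylethyl in place of cyclobutyl on a carbonyl carbon.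

Among the measured compounds shown here, only one measured step bears on this place: (a number 2.00 log units higher from compound 2 to compound 3 (beyond the scatter)), a large step with cyclobutyl in place of pyridin-3-yl on a carbonyl carbon. Here cyclobutyl leaves instead of entering, and the group that enters, like pyridin-3-yl, contains nitrogen. For the measured compounds named here, no measured compound carries 1-(aminomethyl)-1-methylethyl, so this single step is thin support. A large step downward in this assay is therefore expected, of about the same size as that one, and the estimate is (a number 2.10 log units lower from compound 3 to compound 4 (beyond the scatter)). Compound 4 is estimated at (2.6), with an expected range from (1.6) to (3.6).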

Compound 4, distribution coefficient: 1.4
For compound 4 the middle estimate is 1.20 log units above the measured one, outside the stated range (below it).
By their numbers in this assay, from the lowest: compound 4; then compound 2; then compound 3; then compound 1.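

In this assay the place on the carbonyl carbon spans a wider range than compound 2 and compound 3 showed: 1-(aminomethyl)-1-methylethyl in place of cyclobutyl gives a number 3.30 log units lower from compound 3 to compound 4 (beyond the scatter) and sets a new low end for the series. Nitrogen in the entering group does not by itself fix the number, since 1-(aminomethyl)-1-methylethyl in place of pyridin-3-yl still gives a number 1.30 log units lower from compound 2 to compound 4 (beyond the scatter) even though both groups contain nitrogen. Nothing available accounts for the size of either step.

Still open, going by these compounds, is how much of the drop belongs to the primary amine and how much to the open branched chain. A hydroxymethyl in place of the aminomethyl, or a cyclobutyl ring carrying an aminomethyl, would help separate the two.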